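Chloro to Diethylamino: Cytotoxicity Expected to Hold Steady

A few compounds are considered here, and "the series" means these few. Any claim that something is new, unique, unknown or untested is made for them only; others in the source may bear on it.

The study compares three compounds sharing one core. Compound 1 `O=C(CN1CCCC1)Nc1ccc(-c2nc3cc(C(F)(F)F)ccc3[nH]2)cc1` carries a pyrrolidin-1-yl on a saturated chain carbon bound to a carbonyl carbon, and in an ADME assay on MDBK cells (Bos taurus) for cytotoxicity, read by MTT assay, with a stated time of 96 h (on this read-out lower numbers stand for higher toxicity in this test and higher numbers for lower toxicity in this test), compound 1 gives 15000 nM. Compound 2 `O=C(CCl)Nc1ccc(-c2nc3cc(C(F)(F)F)ccc3[nH]2)cc1` carries chloro at that place, and in this assay compound 2 gives 17000 nM, the highest of the two numbers, with compound 1 nearest. The step of a 1.1-fold higher number from compound 1 to compound 2 (0.05 log units; within the scatter) is the only measured one.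

Compound 3 `CCN(CC)CC(=O)Nc1ccc(-c2nc3cc(C(F)(F)F)ccc3[nH]2)cc1` is the next case: diethylamino in place of chloro on a saturated chain carbon bound to a carbonyl carbon. Among the measured compounds shown here, the one step that bears on it, replacing an amine at this place by chloro, stayed within the scatter, so the reverse direction, chloro to a different amine, is expected to move the number by no more than the scatter in either direction. Compound 3 is therefore estimated at 15000 nM, within 7000 nM to 35000 nM, a step of a 1.1-fold lower number from compound 2 to compound 3 (0.05 log units; within the scatter).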

Compound 3, half-maximal cytotoxic concentration: 13000 nM
Beside the measured number, compound 3's estimate is 1.2-fold (0.06 log units) above it; the measured number falls inside the stated range.
By their numbers in this assay, from the lowest: compounds 3, 1 and 2 (each within the scatter of the next).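

In this assay the place on a saturated chain carbon bound to a carbonyl carbon now has a second amine to set against chloro, which gives a 1.3-fold lower number from compound 2 to compound 3 (0.12 log units; within the scatter) and lets the two amines be compared directly, with a 1.2-fold lower number from compound 1 to compound 3 (0.06 log units; within the scatter) for diethylamino in place of pyrrolidin-1-yl. Across these three compounds, neither the exchange of a single chlorine for a group of five heavy atoms nor the exchange of a ring amine for one without a ring takes the number beyond the scatter. Nothing measured here gives a reason for this.

The compounds shown leave open whether a carboxylic acid, a hydroxyl or a longer chain carrying the amine at this place would stay within the scatter as well. They also leave open what a piperidine or a morpholine would give here.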